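The compounds below may be only part of what the source reports. "The series", "measured", "known", "first", "only" and "open" are said of these compounds alone.

Series notes. Compound 1 `C=C1c2c(C)nc(OC)c(C#N)c2N=CN1CC`, compound 2 `C=C1c2c(C)nc(OC)c(C#N)c2N=CN1Cc1ccccc1` and compound 3 `C=C1c2c(C)nc(OC)c(C#N)c2N=CN1Cc1ccc(Cl)cc1` share one core and differ only at the group on the ring nitrogen. In a functional assay on KB cells (Homo sapiens) for cytotoxicity, read by MTT assay, with a stated time of 3 days (a higher number here means a weaker inhibitor, a lower number a stronger inhibitor), compound 1 gives > 50000 nM, which is a limit of the assay and not a number. In this assay compound 2 gives > 50000 nM, again a limit. For the measured compounds named here, compound 3 is the only member with a finite value, giving 20000 nM in this assay. Between the two limits the step that the two limits leave unreadable from compound 1 to compound 2 cannot be read; by contrast an at least 2.5-fold lower number from compound 1 to compound 3 (0.39 log units; beyond the scatter) and an at least 2.5-fold lower number from compound 2 to compound 3 (0.39 log units; beyond the scatter), both bounded by the limit of > 50000 nM in this assay, at which 2 of the 3 values shown sit.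

Compound 4 `C=C1c2c(C)nc(OC)c(C#N)c2N=CN1Cc1ccc(OC)cc1` is not yet measured. The change from compound 3 is methoxy in place of chloro on an aromatic carbon. Going by the values given here, the only measured step at this ring position is an at least 2.5-fold lower number from compound 2 to compound 3 (0.39 log units; beyond the scatter), a chloro for hydrogen; no measured step compares methoxy with chloro or with hydrogen. In this assay the expected step is therefore a 1.8-fold higher number from compound 3 to compound 4 (0.24 log units; within the scatter), weakly upward, with a real chance that only a limit is returned. Compound 4 is expected at 35000 nM, within 12000 nM to 100000 nM.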

Compound 4, half-maximal inhibitory concentration: 670 nM
Compound 4: middle estimate off by 52-fold (1.72 log units), on the high side; the whole stated range lies above it.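

In this assay, the group on this aromatic carbon matters far more than compound 2 and compound 3 could show: methoxy in place of chloro gives a 30-fold lower number from compound 3 to compound 4 (1.47 log units; beyond the scatter), where chloro in place of hydrogen had shown only a modest, bounded gain. Methoxy in place of hydrogen gives an at least 74-fold lower number from compound 2 to compound 4 (1.87 log units; beyond the scatter), and 4-methoxyphenyl in place of methyl gives an at least 74-fold lower number from compound 1 to compound 4 (1.87 log units; beyond the scatter), so among these compounds the group carried on the aromatic ring, and not the ring alone, separates the values. Those two steps are bounded and not exact sizes: the limit of > 50000 nM in this assay, at which 2 of the 4 values shown sit.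

As far as these compounds go, whether the gain belongs to methoxy alone or extends to a hydroxyl, an ethoxy or a dimethylamino group on the same carbon stays open. Also open, from the compounds shown here alone, is whether a longer chain on the ring nitrogen keeps the value of compound 4.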